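This account rests on a few compounds, and the source may have more. Where it says the series, first, only, none or still open, it means among the compounds named here.

Compound 1 `CN(C)CCn1nc(Cc2ccc(Cl)cc2)c2ccccc2c1=O` is the starting point. In an assay for binding affinity to Alpha-1B adrenergic receptor (Homo sapiens) (on this read-out lower numbers stand for stronger inhibition and higher numbers for weaker inhibition), compound 1 gives 200 nM. This is the lowest of the two numbers available: compound 2 `CCCCCc1nn(C[C@H]2CCCN2C)c(=O)c2ccccc12` gives 1000 nM in this assay, a gap that lies beyond the usual scatter of repeated measurements of this kind. Compound 3 `CN(CCCCc1ccc(OCCCN2CCCCCC2)cc1)CCn1nc(Cc2ccc(Cl)cc2)c2ccccc2c1=O` gives only a limit of the assay in this assay, > 1990 nM, so no number is known for it. Going by the values given here, that limit, (the limit of > 1990 nM in this assay, at which 1 of the 3 values shown sits), is the only one among the values here.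

Compound 4 `CN1CCCC1CCn1nc(Cc2ccc(Cl)cc2)c2ccccc2c1=O` has not yet been measured. It differs from compound 1 in one place: 1-methylpyrrolidin-2-yl in place of dimethylamino on a saturated chain carbon, two bonds along the chain from an aromatic nitrogen. Among the compounds with values here, compound 2 carries the same ring in a similar position, but it also differs from compound 1 elsewhere, so its value cannot be read as the effect of this change alone, and no measured step of exactly this kind exists. The expected step, a 1.5-fold higher number from compound 1 to compound 4 (0.18 log units; within the scatter), is small, within or close to the scatter and, if anything, toward weaker binding. Compound 4 is therefore estimated to give 300 nM in this assay, with a likely range from 100 nM to 1000 nM.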

Compound 4, inhibition constant: 316 nM
The estimate for compound 4 lay 1.1-fold (0.02 log units) below the measured number; measured number inside the range.
By their numbers in this assay, from the lowest: compounds 1 and 4 (each within the scatter of the next); then compound 2. At a limit, above all of these: compound 3.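

In this assay, putting 1-methylpyrrolidin-2-yl in place of dimethylamino on a saturated chain carbon, two bonds along the chain from an aromatic nitrogen, gives a 1.6-fold higher number from compound 1 to compound 4 (0.20 log units; within the scatter), so the two compounds cannot be told apart in this measurement. Going by these compounds alone, compound 2 already carried the same ring, but it also differs from compound 1 elsewhere; this pair is the first to isolate the change, and it shows that a five-membered non-aromatic ring can replace the open dimethylamino group here without a change beyond the scatter. Nothing measured here explains this outcome, so the result records what happens at this position but not the reason for it.

This is a single replacement at a single position, so it cannot show how far the tolerance extends. A piperidine or morpholine ring in place of the pyrrolidine, a diethylamino group, or a longer chain leading to the amine could each behave differently, and the values shown give no way to predict them.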